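From isopropoxy to sec-butoxy on a shared core

The source may hold more compounds than are shown below. What is called first, only, known or untested is meant among the compounds shown, and "the series" means these compounds.

In a functional assay on PC-3 cells (Homo sapiens) for antiproliferative activity, read by WST assay, with a stated time of 3 days (on this read-out higher numbers stand for weaker inhibition and lower numbers for stronger inhibition), compound 1 `CCCOc1c(-c2cc(OC)c(OC)c(OC)c2)oc2ccccc2c1=O`, with propyl on an oxygen on an aromatic ring, gives 11800 nM as its value. Compound 2 `CCCCOc1c(-c2cc(OC)c(OC)c(OC)c2)oc2ccccc2c1=O` has butyl in that place and gives 12800 nM as its value. Compound 3 `COc1cc(-c2oc3ccccc3c(=O)c2OC(C)C)cc(OC)c1OC` has isopropyl there and gives 21200 nM as its value. Compound 3 thus stands level with the other two: both a 1.8-fold higher number from compound 1 to compound 3 (0.25 log units; within the scatter) and a 1.7-fold higher number from compound 2 to compound 3 (0.22 log units; within the scatter) are too small to count as real differences.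

Compound 4 `CCC(C)Oc1c(-c2cc(OC)c(OC)c(OC)c2)oc2ccccc2c1=O` differs from compound 3 in one place, (methyl in place of hydrogen on a saturated chain carbon, two bonds along the chain from an oxygen on an aromatic ring), with methyl in place of hydrogen on a saturated chain carbon, two bonds along the chain from an oxygen on an aromatic ring. Isopropoxy thereby becomes sec-butoxy.

Within the data shown here, the closest precedent is the same addition one bond further out, a 1.1-fold higher number from compound 1 to compound 2 (0.04 log units; within the scatter), and it changed nothing measurable. The two steps to compound 3 were also small. Among the measured compounds shown here, no measured compound has a branched chain that was lengthened, so this precedent is only indirect. Still, no step beyond the scatter is expected in this assay, and the estimated step is a 1.2-fold lower number from compound 3 to compound 4 (0.10 log units; within the scatter). For compound 4 the expected value is 17000 nM, with an estimated range from 9000 nM to 32000 nM.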

Compound 4, half-maximal inhibitory concentration: 38600 nM
For compound 4 the middle estimate is 2.3-fold (0.36 log units) below the measured one; the whole stated range lies below it.
By their numbers in this assay, from the lowest: compounds 1, 2, 3 and 4 (each within the scatter of the next, the first and the last beyond it).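

Within this assay, adding the methyl to isopropoxy does not by itself give a real change, as a 1.8-fold higher number from compound 3 to compound 4 (0.26 log units; within the scatter) shows. Among these compounds, the new information is that sec-butyl on this oxygen is the first group here to stand clear of the straight chains, with inhibition modestly weaker in both a 3.0-fold higher number from compound 2 to compound 4 (0.48 log units; beyond the scatter) and a 3.3-fold higher number from compound 1 to compound 4 (0.51 log units; beyond the scatter), while isopropyl remains within the scatter of all three other groups. The single methyl addition therefore cannot be said to act differently on the straight and branched chains, since its two steps agree within the scatter, and the clearer separation appears only when sec-butyl is compared directly with propyl or butyl: the same change on two cores in this assay, a 1.1-fold higher number (0.04 log units; within the scatter) from compound 1 to compound 2 and a 1.8-fold higher number (0.26 log units; within the scatter) from compound 3 to compound 4, 1.7-fold (0.22 log units) apart, within the scatter of two such steps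

With so few compounds, the four values show only a modest drift and cannot establish a general rule that branching on this oxygen weakens inhibition. As far as these compounds go, it remains open how tert-butyl, cyclopentyl or a longer chain such as pentyl would behave at this oxygen, and whether an amine or a carboxylic acid at the end of the chain would move the value further in either direction.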